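Fluoro to hydroxy on the amino-linked phenyl

The source may report more compounds than this note shows. Statements on the series, on what has been measured and on what is new or still open speak of the compounds shown alone.

Compound 1 `Fc1cccc(-c2nc(Nc3ccccc3)c3cc(F)ccc3n2)c1` is the hydrogen-bearing parent of the pair. In a functional assay on MDA-MB-231 cells (Homo sapiens) for cytotoxicity, read by MTT assay, with a stated time of 48 h (a lower number here means a stronger inhibitor, a higher number a weaker inhibitor), compound 1 gives 47800 nM. Compound 2 `Fc1ccc(Nc2nc(-c3cccc(F)c3)nc3ccc(F)cc23)cc1` differs by fluoro in place of hydrogen on an aromatic carbon. In this assay compound 2 gives > 50000 nM, which is a limit of the assay and not a number. The step of an at least 1.0-fold higher number from compound 1 to compound 2 (0.01 log units; that floor lies within the scatter) therefore rests on the limit of > 50000 nM in this assay, at which 1 of the 2 values shown sits, and sets only a floor. Compound 2 thus stands at the weak end of what has been measured, without a number of its own.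

Compound 3 `Oc1ccc(Nc2nc(-c3cccc(F)c3)nc3ccc(F)cc23)cc1` differs from compound 2 by hydroxy in place of fluoro on an aromatic carbon. Within the data shown here, only the step from compound 1 to compound 2 bears on this change, and it is itself unresolved against the limit; no measured step shows what hydroxy does here. For compound 3 the expectation is therefore no step beyond the scatter, an at least 1.2-fold lower number from compound 2 to compound 3 (0.09 log units; that floor lies within the scatter), with wide uncertainty. The estimate for compound 3 in this assay is 40000 nM, between 12000 nM and 120000 nM.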

Compound 3, half-maximal inhibitory concentration: > 50000 nM
Compound 3 gave a limit, no number; the forecaster's own chance of this, stated with the estimate: 50%; at least 1.2-fold (0.09 log units) between middle value and limit.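

Compound 3, like compound 2, returns a limit and not a number in this assay, so replacing 4-fluorophenyl with 4-hydroxyphenyl adds a hydrogen-bond donor without giving a readable change. The step between these two compounds cannot be read because both sit at the same limit: the limit of > 50000 nM in this assay, at which 2 of the 3 values shown sit.

Against the hydrogen-bearing parent, the new record is an at least 1.0-fold higher number from compound 1 to compound 3 (0.01 log units; that floor lies within the scatter), so neither fluoro nor hydroxy at this place, para to a large group, has yet shown a step beyond the scatter.

As far as these compounds go, how far compound 2 and compound 3 lie past the limit remains open, and so does any difference between them. Whether an amine or a carboxylic acid at this place would give a number inside the range of the assay is also unresolved.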